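The source may report more compounds than this note shows. Statements on the series, on what has been measured and on what is new or still open speak of the compounds shown alone.

Working notes on the series.

Of the compounds shown here, two have numbers so far. Compound 1 `CN1C[C@H]2C=C(c3cccnc3)C[C@H](C2)C1` is the reference point of this step; in an in vitro functional assay on SH-EP1 cells for agonist activity at Neuronal acetylcholine receptor; alpha4/beta2 (Homo sapiens), read by voltage clamp (a lower number here means a smaller maximal response, a higher number a larger maximal response), compound 1 gives 19%. Within the data shown here, compound 2 `C1=C(c2cncc(Oc3ccccc3)c2)CC2CNCC1C2` is the only other measured member, and in this assay compound 2 gives 9%. Compound 1 holds the higher of the two numbers, but the gap to compound 2 lies within the scatter of repeated runs, so no order between the two is claimed.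

Compound 3 `CN1C[C@@H]2C=C(c3cccnc3)C[C@@H](C2)C1` has not yet been measured. Its relation to compound 1 is the two compounds have the same atoms and bonds and differ only in configuration as drawn: 2 of 2 stereo elements differ (all stereocentres are inverted: mirror images); a stereocentre at a saturated ring carbon is drawn R in compound 1 and S in compound 3; a stereocentre at a saturated ring carbon is drawn S in compound 1 and R in compound 3. Among the measured compounds shown here, no step between measured compounds is known for this kind of change, so there is no anchor for its size or direction. Mirror-image pairs can give similar or quite different maximal responses, and nothing here tells which applies. The expectation is a step from compound 1 to compound 3 of about a number 4 percentage points lower from compound 1 to compound 3 (within the scatter) in this assay, with little confidence in the sign. Compound 3 is therefore estimated at 15% in this assay, with a plausible range from 3% to 40%.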

Compound 3, largest response reached (reported as percent of maximum), in percent of the reference or control that the assay uses: 18%
Estimate against measurement, compound 3: 3 percentage points below; the measured number falls inside the stated range.
By their numbers in this assay, from the lowest: compounds 2, 3 and 1 (each within the scatter of the next).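

Inverting both stereocentres gives the first readable step in the series: in this assay, the mirror-image change amounts to a number 1 percentage points lower from compound 1 to compound 3 (within the scatter). At this level of maximal response, the drawn configuration therefore does not separate the two compounds, and neither mirror image can be ranked above the other in this assay. The comparison is a clean one, with no other structural variable entering the pair: the fact that compounds 1 and 3 differ only in the configuration as drawn.

On these data alone, the pair speaks only for the methyl-substituted amine and the unsubstituted aromatic ring of compound 1, so it remains open whether mirror images would stay this close with an ethyl group in place of that methyl group, or with an amine or a carboxylic acid on the aromatic ring. The result also gives no cause for the closeness of the two numbers, and it says nothing about how either mirror image would behave in any read-out other than this assay.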